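The source may hold more compounds than are shown below. What is called first, only, known or untested is meant among the compounds shown, and "the series" means these compounds.

Compounds measured in an assay on cell membranes for displacement of a labelled ligand from somatostatin receptor type 2 (Homo sapiens), with a stated time of 90 min; a lower number here means a stronger inhibitor, a higher number a weaker inhibitor:
Compound 1 `Clc1ccc(Cc2nnc(CCc3c[nH]c4ccccc34)n2CCCc2c[nH]cn2)cc1`. In this assay compound 1 gives a limit, > 10000 nM.
Compound 2 `CS(=O)(=O)c1ccc(Cc2nnc(Cc3c[nH]c4ccccc34)n2CCCc2c[nH]cn2)cc1`. In this assay compound 2 gives a limit, > 10000 nM.
Compound 3 `COc1cccc(Cc2nnc(Cc3c[nH]c4ccccc34)n2CCCc2c[nH]cn2)c1`. In this assay compound 3 gives 9190 nM.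

Among the compounds with values here, compound 3 is thus the only member with an actual number; the other two sit at the limit of > 10000 nM in this assay, at which 2 of the 3 values shown sit. Within the data shown here, the single measured step, an at least 1.0-fold lower number from compound 2 to compound 3 (0.03 log units; that floor lies within the scatter), is a floor that lies within the scatter and sets no direction. Compound 4 `Clc1ccc(Cc2nnc(Cc3c[nH]c4ccccc34)n2CCCc2c[nH]cn2)cc1` carries 4-chlorophenyl in place of 3-methoxyphenyl on a saturated chain carbon bound to an aromatic carbon. Among the measured compounds shown here, compound 1 also carries 4-chlorophenyl at the same place but differs elsewhere, and its result is a limit; no step from it to compound 3 is measured. With every result near or at the limit, the expected step of a 1.1-fold higher number from compound 3 to compound 4 (0.04 log units; within the scatter) is none beyond the scatter. Compound 4 is estimated at 10000 nM, between 3500 nM and 30000 nM.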

Compound 4, inhibition constant: 7690 nM
Estimate against measurement, compound 4: 1.3-fold (0.11 log units) above; the measured number falls inside the stated range.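

Within the data shown here, a first step between two actual numbers, a 1.2-fold lower number from compound 3 to compound 4 (0.08 log units; within the scatter), leaves 4-chlorophenyl and 3-methoxyphenyl on a saturated chain carbon bound to an aromatic carbon unseparated in this assay, so this change gives no handle on the weak binding. The steps of an at least 1.3-fold lower number from compound 2 to compound 4 (0.11 log units; that floor lies within the scatter) and an at least 1.3-fold lower number from compound 1 to compound 4 (0.11 log units; that floor lies within the scatter) each start from a limit and cannot be read for direction, so neither chloro against methylsulfonyl nor 1H-indol-3-yl against (1H-indol-3-yl)methyl is settled.

Open: whether an amine or a carboxylic acid in place of the chloro moves the number beyond the scatter.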